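A few compounds are considered here, and "the series" means these few. Any claim that something is new, unique, unknown or untested is made for them only; others in the source may bear on it.

In a functional assay on MCF7 cells (Homo sapiens) for antiproliferative activity, read by CCK-8 assay, with a stated time of 72 h (on this read-out higher numbers stand for weaker inhibition of growth and lower numbers for stronger inhibition of growth), compound 1 (`CCC1C(=O)N(C)c2cnc(-n3ccc4cc(C(=O)NC(C)C)ccc43)nc2N1c1ccn(C)n1`) gives 8420 nM, while compound 2 (`CCC1C(=O)N(C)c2cnc(-n3ccc4cc(F)ccc43)nc2N1c1ccn(C)n1`) gives 24700 nM, the highest of the two numbers. Compound 3 (`CCCCNC(=O)c1ccc2c(ccn2-c2ncc3c(n2)N(c2ccn(C)n2)C(CC)C(=O)N3C)c1`) differs from compound 2 by butylcarbamoyl in place of fluoro on an aromatic carbon. Going by the values given here, the one measured step bearing on this is a 2.9-fold higher number from compound 1 to compound 2 (0.47 log units; beyond the scatter), modest but beyond the scatter, with fluoro in place of isopropylcarbamoyl. A step of similar size in the opposite direction, toward a lower number, is therefore expected in this assay. The expected change is a 2.9-fold lower number from compound 2 to compound 3 (0.46 log units; beyond the scatter). Compound 3 is estimated at 8500 nM, with an expected range of 3000 nM to 22000 nM.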

Compound 3, concentration for 50% growth inhibition: 8990 nM
Estimate against measurement, compound 3: 1.1-fold (0.02 log units) below; low and high end bracket the measured number.
By their numbers in this assay, from the lowest: compounds 1 and 3 (each within the scatter of the next); then compound 2.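

In this assay, butylcarbamoyl in place of fluoro on this aromatic carbon gives a 2.7-fold lower number from compound 2 to compound 3 (0.44 log units; beyond the scatter), so a second carbamoyl group also stands with a lower number than fluoro. Butyl in place of isopropyl on the amide-type nitrogen gives a 1.1-fold higher number from compound 1 to compound 3 (0.03 log units; within the scatter), so these two chains cannot be told apart here. Nothing shown explains these numbers.

The compounds shown leave open how a carboxylic acid at this aromatic carbon would compare with the carbamoyl groups. They also leave open what a longer chain or a terminal amine on the amide-type nitrogen would do.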